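This account rests on a few compounds, and the source may have more. Where it says the series, first, only, none or still open, it means among the compounds named here.

Compound 1, `Nc1nc(NC2CCCCC2)c2ncn(/C=C3/CC3(CO)CO)c2n1`: in an ADME assay on Akata cells (Homo sapiens) for cytotoxicity, with a stated time of 7 days (a lower number here means that less compound is tolerated, a higher number that more compound is tolerated), compound 1 gives > 24000 nM, a limit of the assay rather than a number.
Compound 2, `Nc1nc(NCc2ccccc2)c2ncn(/C=C3/CC3(CO)CO)c2n1`: in this assay compound 2 gives > 24000 nM, again a limit of the assay.
Compound 3, `Nc1nc(N2CCCC2)c2ncn(/C=C3/CC3(CO)CO)c2n1`: in this assay compound 3 gives > 24000 nM, also a limit of the assay.

Compound 3 therefore stands where every measured compound of this set stands, at the limit of > 24000 nM in this assay, at which 3 of the 3 values shown sit; there is no number that would set it apart from compound 1 or compound 2. The step from compound 3 to compound 4, `Nc1nc(NC2CCCC2)c2ncn(/C=C3/CC3(CO)CO)c2n1`, is cyclopentylamino in place of pyrrolidin-1-yl on an aromatic carbon. The measured steps around the same position give no size to lean on: a step that the two limits leave unreadable from compound 1 to compound 2, a step that the two limits leave unreadable from compound 1 to compound 3 and a step that the two limits leave unreadable from compound 2 to compound 3 all remain unreadable, since both ends of each sit at the same limit. With three different groups at that carbon all tolerated up to the limit, the expectation for compound 4 is no step beyond the scatter in this assay, and most probably one more limit. Compound 4 is therefore estimated to give 30000 nM in this assay, within 15000 nM to 100000 nM, which corresponds to an expected step that the limit leaves unreadable from compound 3 to compound 4.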

Compound 4, half-maximal cytotoxic concentration: > 20000 nM
Compound 4: no number, only a limit (the forecaster's own chance of this, stated with the estimate: 85%); the middle value lies beyond the limit too.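

In this assay compound 4 gives > 20000 nM, a limit of the assay and not a number. Its steps from compound 1, compound 2 and compound 3 cannot be read, since all four compounds sit at limits. The compounds shown leave open where their half-maximal cytotoxic concentrations lie and whether the groups at that aromatic carbon differ at all.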